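Swapping methoxy for methyl at an assay limit

The compounds below may be only part of what the source reports. "The series", "measured", "known", "first", "only" and "open" are said of these compounds alone.

Measured so far in a functional assay on L5178Y cells (Mus musculus) for inhibition, read by MTT assay, with a stated time of 72 h; on this read-out lower numbers stand for stronger inhibition and higher numbers for weaker inhibition:
Compound 1 `C[Se]C(=O)c1ccc(C(=O)[Se]C)s1` gives > 100000 nM as a limit
Compound 2 `COC(=O)C[Se]C(=O)c1ccc(Cl)cc1` gives > 100000 nM as a limit

Compound 2 gives > 100000 nM as a limit of the assay and not a number. Compound 1 gives > 100000 nM as a limit too. Neither compound therefore has an actual potency number (the limit of > 100000 nM in this assay, at which 2 of the 2 values shown sit). Among the compounds with values here, the two compounds also differ in more than one place, so no measured step offers a guide.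

Compound 3 `CC(=O)C[Se]C(=O)c1ccc(Cl)cc1` differs from compound 2 in one place, with methyl in place of methoxy on a carbonyl carbon. The same difference reads as methoxycarbonyl to acetyl.

In this assay the expected change an at least 3.3-fold lower number from compound 2 to compound 3 (0.52 log units; beyond the scatter) runs towards stronger inhibition, but this is a tentative expectation and its size is poorly fixed. A second result at the limit remains quite possible. The estimate for compound 3 is 30000 nM with 2000 nM as the expected lower end and 100000 nM as the expected upper end.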

Compound 3, half-maximal inhibitory concentration: 780 nM
The estimate for compound 3 lay 38-fold (1.59 log units) above the measured number, and the stated range ends above it.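

In this assay, within the data shown here, replacing methoxy with methyl on a carbonyl carbon gives an at least 120-fold lower number from compound 2 to compound 3 (2.10 log units; beyond the scatter), the first step that can be read here and the first result that is an actual number rather than a limit. The earlier compounds shown here could not show this, as neither gave a number and they differed in more than one place; now it is clear that this position, on a carbonyl carbon whose other neighbour is a saturated chain carbon, is not indifferent, and that one small swap with the rest of the structure unchanged can move a compound from the limit of the assay to a readable value. The true size of the step stays unknown because compound 2 stands at a limit and not at a number: the limit of > 100000 nM in this assay, at which 2 of the 3 values shown sit.

A single step cannot tell whether the methyl itself matters or whether losing the methoxy is what counts, a question that an ethyl group or an amine on the same carbonyl carbon would help to settle. On these data alone, it also remains open whether the change from methoxycarbonyl to acetyl would have a similar effect on a different core.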